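A Methyl Added to a Compound at the Assay Limit

The source may report more compounds than this note shows. Statements on the series, on what has been measured and on what is new or still open speak of the compounds shown alone.

Compound 1 `Cc1ccccc1Nc1nc(NC2CC2)ncc1Cl`: > 100000 nM
Compound 2 `CN1CCN(c2ccc(Nc3ncc(Cl)c(Nc4ccccc4)n3)nc2)CC1`: > 100000 nM

In a functional assay on Jurkat cells (Homo sapiens) for inhibition, read by CCK-8 assay, with a stated time of 48 h (a higher number here means a weaker inhibitor of growth, a lower number a stronger inhibitor of growth), compound 1 reaches only the limit of the measurement, > 100000 nM, so no number is known for it. Compound 2 likewise reaches only the limit in this assay, > 100000 nM; it stands where both values given so far sit, namely (the limit of > 100000 nM in this assay, at which 2 of the 2 values shown sit). Within the data shown here, neither compound is strong enough to yield a number, and no step between two numbers exists to show how a change in structure moves the result.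

Compound 3 `Cc1ccc(Nc2nc(Nc3ccc(N4CCN(C)CC4)cn3)ncc2Cl)cc1` differs from compound 2 by methyl in place of hydrogen on an aromatic carbon. With both known values at the limit, no step beyond the usual scatter is expected in this assay, and compound 3 is expected to reach the limit again, meaning the step of a number no higher from compound 2 to compound 3 (the limit leaves the size open) is taken as no change. Compound 3 is therefore estimated at 100000 nM, within 30000 nM to 300000 nM.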

Compound 3, concentration for 50% growth inhibition: 30900 nM
Compound 3: the middle estimate sits 3.2-fold (0.51 log units) above what was measured, within the range that was stated.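

Among these compounds, compound 3 is the only compound so far to give a real number rather than a limit, which shows that growth inhibition in this assay can be reached. The change from phenyl to 4-methylphenyl, one added carbon placed para to a large group, gives an at least 3.2-fold lower number from compound 2 to compound 3 (0.51 log units; beyond the scatter). That size is a minimum, and most of the values still offer no number to compare: the limit of > 100000 nM in this assay, at which 2 of the 3 values shown sit.

As far as these compounds go, whether a longer chain such as ethyl, a methoxy group or a chlorine atom in the same place would lower the number further remains open. The compounds shown also hold no second pair with this same change, so it is unknown whether the step would recur on a different partner structure.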